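This account rests on a few compounds, and the source may have more. Where it says the series, first, only, none or still open, it means among the compounds named here.

Compound 2 `COc1cc(/C=C/C(=O)c2sc(Nc3ccccc3)nc2C)cc(OC)c1OC` is a member of a small series tested in a functional assay on PC-3 cells (Homo sapiens) for cytotoxicity, read by MTT assay; a higher number here means a weaker inhibitor, a lower number a stronger inhibitor. In this assay compound 2 gives > 25000 nM, which is a limit of the assay and not a measured number. Its neighbour compound 1 `COc1cc(/C=C/C(=O)c2sc(Nc3ccc(Cl)cc3)nc2C)cc(OC)c1OC` differs from it only by a chloro group on the anilino ring. In this assay compound 1 gives > 25000 nM, again a limit rather than a number. The step that the two limits leave unreadable from compound 1 to compound 2 therefore carries no readable size because of the limit of > 25000 nM in this assay, at which 2 of the 2 values shown sit.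

Compound 3 `COc1cc(/C=C/C(=O)c2sc(Nc3ccc(C)cc3)nc2C)cc(OC)c1OC` is not yet measured. It differs from compound 2 by methyl in place of hydrogen on an aromatic carbon, para to a large group on the anilino ring. Among the measured compounds shown here, the only measured step touching this ring, from chloro to hydrogen, is unreadable, so no size in either direction can be taken from it. The step that the limit leaves unreadable from compound 2 to compound 3 is therefore expected to be none beyond the scatter, with compound 3 most likely reported only as a limit. Compound 3 is estimated at 30000 nM, within a range from 10000 nM to 100000 nM.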

Compound 3, half-maximal inhibitory concentration: > 25000 nM
Compound 3: a limit, no number (the forecaster's own chance of this, stated with the estimate: 80%); the middle value lies beyond the limit too.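

In this assay compound 3 gives > 25000 nM, which is a limit and not a number. No step among compound 1, compound 2 and compound 3 can be read, because each value is a limit: the limit of > 25000 nM in this assay, at which 3 of the 3 values shown sit.

The compounds shown leave open whether chloro, hydrogen or methyl on the anilino ring makes any difference to the read-out.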